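From 4-fluorophenyl to 4-bromo-2-fluorophenyl on a sulfonyl sulfur

A few compounds are considered here, and "the series" means these few. Any claim that something is new, unique, unknown or untested is made for them only; others in the source may bear on it.

Three compounds share one core and differ only in the group on the sulfonyl sulfur: compound 1 `CCS(=O)(=O)N1CCC2(CC1)OOC1(CCCC1)OO2`, compound 2 `COc1ccc(S(=O)(=O)N2CCC3(CC2)OOC2(CCCC2)OO3)cc1` and compound 3 `O=S(=O)(c1ccc(F)cc1)N1CCC2(CC1)OOC1(CCCC1)OO2`. All three were tested in a functional assay on Huh-7 cells (Homo sapiens) for cytotoxicity, read by MTT assay, with a stated time of 72 h; on this read-out lower numbers stand for higher toxicity in this test and higher numbers for lower toxicity in this test. Compound 1 gives > 100 ug/mL, which is a limit of the assay. Compound 2 gives > 100 ug/mL, again a limit. Compound 3 gives > 100 ug/mL, also a limit and not a number. The whole set so far stands at the limit of > 100 ug/mL in this assay, at which 3 of the 3 values shown sit.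

Compound 4 `O=S(=O)(c1ccc(Br)cc1F)N1CCC2(CC1)OOC1(CCCC1)OO2` carries 4-bromo-2-fluorophenyl in place of 4-fluorophenyl, on a sulfonyl sulfur (4-bromo-2-fluorophenyl in place of 4-fluorophenyl on a sulfonyl sulfur). Among the compounds with values here, two measured steps bear on this change: a step that the two limits leave unreadable from compound 1 to compound 3 and a step that the two limits leave unreadable from compound 2 to compound 3. Neither has a readable size, so neither shows any movement away from the limit. In this assay no step beyond the scatter is therefore expected, and the estimated change, in neither direction, is a number no higher from compound 3 to compound 4 (the limit leaves the size open). The estimate for compound 4 is 100 ug/mL, with an expected range from 50 ug/mL to 200 ug/mL.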

Compound 4, half-maximal cytotoxic concentration: > 100 ug/mL
Compound 4: a limit, no number (the forecaster's own chance of this, stated with the estimate: 80%); the middle value lies on the limit itself.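

The steps from compound 1, compound 2 and compound 3 to compound 4 cannot be read, as all four compounds stand at a limit and not a number: the limit of > 100 ug/mL in this assay, at which 4 of the 4 values shown sit.

The compounds shown leave open whether any group on the sulfonyl sulfur changes the value in this assay, and by how much.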